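Methoxy on the fused core of compound 2

This account rests on a few compounds, and the source may have more. Where it says the series, first, only, none or still open, it means among the compounds named here.

Compound 2 `O=C(Nc1ccc(-n2ncc3ccccc32)cc1)Nc1ccc(Cl)c(C(F)(F)F)c1` gives 18200 nM in a functional assay on HT-29 cells (Homo sapiens) for cytotoxicity, read by MTT assay, with a stated time of 72 h (a lower number here means a stronger inhibitor, a higher number a weaker inhibitor), the highest of the two numbers in hand. Among the measured compounds shown here, its nearest neighbour is compound 1 `O=C(Nc1ccc(-n2ncc3c(C(F)(F)F)cccc32)cc1)Nc1ccc(Cl)c(C(F)(F)F)c1`, which in this assay gives 2900 nM; the step of a 6.3-fold higher number from compound 1 to compound 2 (0.80 log units; beyond the scatter) is the only one the pair allows. Compound 3 `COc1cccc2c1cnn2-c1ccc(NC(=O)Nc2ccc(Cl)c(C(F)(F)F)c2)cc1` differs from compound 2 by methoxy in place of hydrogen on an aromatic carbon. For the measured compounds named here, the one measured step that bears on this is the removal of trifluoromethyl from the fused core, a 6.3-fold higher number from compound 1 to compound 2 (0.80 log units; beyond the scatter), which took the number up well beyond the scatter; it shows that a substituent on that carbon ring of the core matters, but it concerns trifluoromethyl, not methoxy, so the size carried over is uncertain. A substituent entering the same kind of position is expected to move the number down, but by less than the trifluoromethyl step. Going by the values given here, the group that enters is methoxy, not trifluoromethyl, and no measured step shows what methoxy does here. The step of a 2.3-fold lower number from compound 2 to compound 3 (0.36 log units; beyond the scatter) is the expected direction and size. For compound 3 the estimate is 8000 nM, with a range from 3000 nM to 20000 nM.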

Compound 3, half-maximal inhibitory concentration: > 32000 nM
Compound 3 was reported as a limit; the forecaster's own chance of this, stated with the estimate: 5%; middle value at least 4.0-fold (0.60 log units) away from the limit.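

Compound 3 is reported only as a limit in this assay: the limit of > 32000 nM in this assay, at which 1 of the 3 values shown sits.

Even as a limit, it gives the step of an at least 1.7-fold higher number from compound 2 to compound 3 (0.24 log units; that floor lies within the scatter), so methoxy on this aromatic carbon brings no lower number than hydrogen, although the floor of that step does not establish a real rise over hydrogen. Against trifluoromethyl at the same carbon the picture is clearer, with an at least 11-fold higher number from compound 1 to compound 3 (1.04 log units; beyond the scatter), and this shows that the lower number of compound 1 does not follow from simply having a substituent on this carbon: among the three groups shown, only trifluoromethyl gives it.

The compounds shown leave open whether another group on this carbon, such as a nitrile, an amine or an ethyl group, would keep the lower number of compound 1 or fall with methoxy. They also leave open how far the true number of compound 3 lies beyond its limit, and whether methoxy on another carbon of the same six-membered aromatic ring would give the same outcome.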